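Ethyl to Propyl on the Amide of Compound 2

The compounds below may be only part of what the source reports. "The series", "measured", "known", "first", "only" and "open" are said of these compounds alone.

Compound 1 `CCNC(=O)c1cc(Oc2ccc(NC(=O)c3cc4cccnc4n(-c4ccccc4)c3=O)cc2)ccn1` gives 220 nM in a functional assay on HT-29 cells (Homo sapiens) for antiproliferative activity, read by MTT assay, with a stated time of 72 h; on this read-out lower numbers stand for stronger inhibition and higher numbers for weaker inhibition.
Compound 2 `CCNC(=O)c1cc(Oc2ccc(NC(=O)c3cc4cccnc4n(-c4ccc(Br)cc4)c3=O)cc2)ccn1` gives 1160 nM in this assay.
Compound 3 `CCNC(=O)c1cc(Oc2ccc(NC(=O)c3cc4cccnc4n(-c4ccc(C(F)(F)F)cc4Cl)c3=O)cc2)ccn1` gives 4770 nM in this assay.

Compound 2 stands second highest of the three numbers. Its nearest neighbour is compound 3, reached by a 4.1-fold higher number from compound 2 to compound 3 (0.61 log units; beyond the scatter); its furthest is compound 1, from which it is reached by a 5.3-fold higher number from compound 1 to compound 2 (0.72 log units; beyond the scatter). Both of these steps, and also a 22-fold higher number from compound 1 to compound 3 (1.34 log units; beyond the scatter), change only the group on the aromatic nitrogen of the shared core.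

Compound 4 `CCCNC(=O)c1cc(Oc2ccc(NC(=O)c3cc4cccnc4n(-c4ccc(Br)cc4)c3=O)cc2)ccn1` differs from compound 2 in another place: methyl in place of hydrogen on a saturated chain carbon, two bonds along the chain from an amide-type nitrogen. For the measured compounds named here, no measured pair changes this chain, so none of the three steps bears directly on it; the steps that exist are modest to large but concern a different part of the molecule. With nothing in the data pointing either way, the chain lengthening is expected to leave the number where compound 2 stands, giving an expected 1.0-fold higher number from compound 2 to compound 4 (0.01 log units; within the scatter), that is no step beyond the scatter. Compound 4 is therefore estimated at 1200 nM, with a range from 500 nM to 3000 nM.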

Compound 4, half-maximal inhibitory concentration: 530 nM
The estimate for compound 4 lay 2.3-fold (0.35 log units) above the measured number; measured number inside the range.
By their numbers in this assay, from the lowest: compound 1; then compound 4; then compound 2; then compound 3.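

Going from ethyl to propyl in this assay gives a 2.2-fold lower number from compound 2 to compound 4 (0.34 log units; beyond the scatter), so the chain on the amide-type nitrogen is a second place in this series where one change moves the number beyond the scatter. For the compounds shown here, a single methyl, added on a saturated chain carbon, two bonds along the chain from that nitrogen, moves the number in the direction of stronger inhibition, whereas the earlier steps concerned only the group on the aromatic nitrogen. Nothing available accounts for this step.

The compounds shown leave open whether a butyl chain, or a chain ending in a hydroxyl group or an amine, would take the number further down or bring it back up. They also leave open whether the same lengthening would act alike with the phenyl of compound 1 or the 2-chloro-4-(trifluoromethyl)phenyl of compound 3 on the aromatic nitrogen.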